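Cytotoxicity of methoxy versus nitro on the aryl hydrazone

A few compounds are considered here, and "the series" means these few. Any claim that something is new, unique, unknown or untested is made for them only; others in the source may bear on it.

Measured compounds:
Compound 1 `COc1ccc(/C=N/NC(=O)CSc2nnnn2C)cc1` – > 10000000 nM
Compound 2 `Cn1nnnc1SCC(=O)N/N=C/c1cccc([N+](=O)[O-])c1` – 2000000 nM
Compound 3 `Cn1nnnc1SCC(=O)N/N=C/c1ccccc1Br` – 20000 nM

These compounds were tested in an ADME assay on NIH3T3 cells (Mus musculus) for cytotoxicity, read by XTT assay, with a stated time of 24 h; on this read-out higher numbers stand for weaker inhibition and lower numbers for stronger inhibition. Compound 1 gives > 10000000 nM, which is a limit of the assay rather than a number. Among the two actual numbers, compound 2 stands at the top with 2000000 nM, while compound 3 gives 20000 nM, a gap well beyond the usual scatter. Compound 2 is therefore the weaker inhibitor of the two numbered compounds in this assay.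

The unmeasured compound 4 `COc1cccc(/C=N/NC(=O)CSc2nnnn2C)c1` differs from compound 2 in one place: methoxy in place of nitro on an aromatic carbon, meta to a large group. For the measured compounds named here, no measured pair shows this exact change, so the size of the step is uncertain. Compound 1 also carries a methoxy on the same ring and sits at the limit of the assay, which suggests the change will not make inhibition stronger. Compound 4 is expected to give 4000000 nM, between 1000000 nM and 20000000 nM, an estimated step of a 2.0-fold higher number from compound 2 to compound 4 (0.30 log units; within the scatter).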

Compound 4, half-maximal inhibitory concentration: 600000 nM
Compound 4: the middle estimate sits 6.7-fold (0.82 log units) above what was measured; the measured number lies below the stated range.
By their numbers in this assay, from the lowest: compound 3; then compound 4; then compound 2. At a limit, above all of these: compound 1.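

In this assay, methoxy in place of nitro on an aromatic carbon, meta to a large group, gives a 3.3-fold lower number from compound 2 to compound 4 (0.52 log units; beyond the scatter), so at this position the change moves the number towards stronger inhibition, not weaker. Compound 1, which also carries a methoxy on the ring, gives > 10000000 nM, a limit of the assay and not a number. Compound 4 gives a real number, so a methoxy on this ring does not by itself place a compound at that limit: the limit of > 10000000 nM in this assay, at which 1 of the 4 values shown sits.

The compounds shown leave open whether another group at this position, such as an amine or a carboxylic acid, would move the number further, and they offer no explanation for this step. Nor do they tell how far apart compound 1 and compound 4 really lie.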